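Hydroxypyridinyl amide in place of thiazolyl amide

The compounds below may be only part of what the source reports. "The series", "measured", "known", "first", "only" and "open" are said of these compounds alone.

Compound 1 `O=C(Nc1ccc(Cl)cc1CN1C(=O)c2ccccc2C1=O)c1cccnc1` and compound 2 `O=C(Nc1ccc(Cl)cc1CN1C(=O)c2ccccc2C1=O)c1cncs1` share one core and differ only in the ring attached on a carbonyl carbon. In an assay on CHO cells for positive allosteric modulation of metabotropic glutamate receptor 5 (Rattus norvegicus), read by FLIPR (a higher number here means that more compound is needed for the effect, a lower number that less compound is needed), compound 1 gives < 1000 nM, which is a limit of the assay rather than a number. In this assay compound 2 likewise gives < 1000 nM, again a limit and not a number. The step that the two limits leave unreadable from compound 1 to compound 2 therefore cannot be read, as the limit of < 1000 nM in this assay, at which 2 of the 2 values shown sit, makes plain. Compound 3 `O=C(Nc1ccc(Cl)cc1CN1C(=O)c2ccccc2C1=O)c1ncccc1O` differs from compound 2 in that (3-hydroxypyridin-2-yl in place of 1,3-thiazol-5-yl on a carbonyl carbon). Among the measured compounds shown here, the only measured step, from compound 1 to compound 2, also exchanges the ring on a carbonyl carbon, but with both values sitting at the limit it gives no size for a step in this assay, in either direction, and no sign that such an exchange moves the value beyond the scatter. Compound 3 is therefore expected to give about 300 nM, within a range from 30 nM to 3000 nM. The expected step is a step that the limit leaves unreadable from compound 2 to compound 3, with a limit again the likeliest report.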

Compound 3, half-maximal effective concentration: < 1000 nM
Compound 3 gave a limit, no number (the forecaster's own chance of this, stated with the estimate: 60%); the middle value is on the limit's open side.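

In this assay compound 3 gives < 1000 nM, a limit of the assay and not a number. The steps joining compound 1 and compound 2 to compound 3 therefore cannot be read, because every value sits at one limit: the limit of < 1000 nM in this assay, at which 3 of the 3 values shown sit. The compounds shown leave open whether exchanging the ring on the carbonyl carbon moves the value in this assay at all.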